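Chlorostyryl arm replaces triazolylmethyl on the shared core

The compounds below may be only part of what the source reports. "The series", "measured", "known", "first", "only" and "open" are said of these compounds alone.

Compound 1 `NS(=O)(=O)c1cc(-c2nnc(CN3CCN(Cc4ccccc4)CC3)o2)c(Cl)cc1SCc1ccccc1` gives 125000 nM in a functional assay on MCF7 cells (Homo sapiens) for cytotoxicity, read by MTT assay, with a stated time of 72 h; a lower number here means a stronger inhibitor, a higher number a weaker inhibitor.
Compound 2 `NS(=O)(=O)c1cc(-c2nnc(CN3CCN(c4ccc(F)cc4)CC3)o2)c(Cl)cc1SCc1ccccc1` gives 240000 nM in this assay.
Compound 3 `CCOC(=O)c1cn(Cc2nnc(-c3cc(S(N)(=O)=O)c(SCc4ccccc4)cc3Cl)o2)nn1` gives 150000 nM in this assay.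

Compound 3 holds the second highest of the three numbers, yet all three lie within the scatter of one another, so none can be called stronger or weaker. Going by the values given here, the only measured step, a 1.9-fold higher number from compound 1 to compound 2 (0.28 log units; within the scatter), alters the group on the amine nitrogen in the ring and tells nothing about the position changed here. Compound 4 `NS(=O)(=O)c1cc(-c2nnc(/C=C/c3cccc(Cl)c3)o2)c(Cl)cc1SCc1ccccc1` differs from compound 3 by 2-(3-chlorophenyl)ethenyl in place of (4-(ethoxycarbonyl)-1H-1,2,3-triazol-1-yl)methyl on an aromatic carbon. Among the compounds with values here, no measured step bears on this change, so no shift beyond the scatter is expected in either direction. Compound 4 is therefore estimated at 150000 nM, within 50000 nM to 450000 nM. The expected step is no change at the digits printed from compound 3 to compound 4 (within the scatter), within the scatter.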

Compound 4, half-maximal inhibitory concentration: 11000 nM
Beside the measured number, compound 4's estimate is 14-fold (1.13 log units) above it; measured number below the stated range.
By their numbers in this assay, from the lowest: compound 4; then compounds 1, 3 and 2 (each within the scatter of the next).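

Replacing (4-(ethoxycarbonyl)-1H-1,2,3-triazol-1-yl)methyl with 2-(3-chlorophenyl)ethenyl gives a 14-fold lower number from compound 3 to compound 4 (1.13 log units; beyond the scatter) in this assay, so the group on this aromatic carbon can shift the number well beyond the scatter, which the earlier step on the amine nitrogen did not show. The swap changes the ring type and adds chlorine in one move, and nothing available explains the drop.

Going by these compounds, it remains open which part of the new arm matters. A plain phenyl without chlorine, a longer chain or an amine on this carbon would help to separate these parts.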